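Efficacy notes: hydroxyphenyl to fluorophenyl on the piperidine carbon

The compounds below may be only part of what the source reports. "The series", "measured", "known", "first", "only" and "open" are said of these compounds alone.

Of the compounds shown here, three have been read in a functional assay on HEK293 cells for agonist activity at D(4) dopamine receptor (Homo sapiens), read by FLIPR; a lower number here means a smaller maximal response, a higher number a larger maximal response. Compound 1 `Cc1cccc(NC(=O)CN2CCC(c3ccc(O)cc3)CC2)c1` gives 60% in this assay, the highest of the three numbers. Compound 2 `O=C(CN1CCC(c2cccc[n+]2[O-])CC1)NC1CCCCC1` gives 58% in this assay, which lies within the scatter of compound 1 and so cannot be ordered against it. Compound 3 `CC(C)Oc1cccc(NC(=O)CN2CCC(c3cccc[n+]3[O-])CC2)c1` gives 48% in this assay, a number beyond the scatter below compound 1. For the measured compounds named here, no single-point step between measured compounds is available, so no measured size of change can be quoted.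

Compound 4 `Cc1cccc(NC(=O)CN2CCC(c3cccc(F)c3)CC2)c1` is not yet measured. It differs from compound 1 as follows: 3-fluorophenyl in place of 4-hydroxyphenyl on a saturated ring carbon. Going by the values given here, the change removes the only hydrogen-bond donor and acceptor of the leaving group, but nothing among the measured compounds isolates the effect of that exchange.

For compound 4 the expected step in this assay is a number 10 percentage points lower from compound 1 to compound 4 (within the scatter), a small downward move that stays within the scatter. Compound 4 is therefore estimated at 50%, with a range of 30% to 70%.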

Compound 4, largest response reached (reported as efficacy), in percent of the reference or control that the assay uses: 40%
Compound 4: the middle estimate sits 10 percentage points above what was measured, within the range that was stated.
By their numbers in this assay, from the lowest: compounds 4, 3, 2 and 1 (each within the scatter of the next, the first and the last beyond it).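

For the compounds shown here, on the saturated ring carbon, the aryl group bears on the maximal response: in this assay the exchange of 4-hydroxyphenyl for 3-fluorophenyl gives a number 20 percentage points lower from compound 1 to compound 4 (beyond the scatter), the first single-place step. The entering group has no hydrogen-bond donor or acceptor, yet compound 4 still gives 40%, so a response remains without those counted on the leaving group. No supporting measurement bears on why the number falls.

From the compounds shown here alone, the exchange alters both the substituent and its numbered place on the phenyl ring, so the share of each in the step stays open; a plain phenyl group on the same carbon of the core of compound 1 would help separate them. Going by these compounds, how an amine or a carboxylic acid on that phenyl ring would read also remains open.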